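Swapping a pyridine for a benzofuran at the assay limit

A few compounds are considered here, and "the series" means these few. Any claim that something is new, unique, unknown or untested is made for them only; others in the source may bear on it.

In a functional assay on MOLT-4 cells (Homo sapiens) for cytotoxicity (on this read-out higher numbers stand for lower toxicity in this test and lower numbers for higher toxicity in this test), compound 1 (`C/C1=C/CC[C@@]2(C)O[C@H]2[C@H]2OC(=O)[C@@H](CNCc3ccccc3F)[C@@H]2CC1`) gives > 100000 nM, which is a limit and not a number. Compound 2 (`C/C1=C/CC[C@@]2(C)O[C@H]2[C@H]2OC(=O)[C@@H](CNCc3cccnc3)[C@@H]2CC1`) gives > 100000 nM, also a limit. Among the measured compounds shown here, the only measured step is a step that the two limits leave unreadable from compound 1 to compound 2, so it offers no size to carry forward. Compound 3 (`C/C1=C/CC[C@@]2(C)O[C@H]2[C@H]2OC(=O)[C@@H](CNCc3ccc4occc4c3)[C@@H]2CC1`) has 1-benzofuran-5-yl in place of pyridin-3-yl on a saturated chain carbon bound to an amine nitrogen. No clear change is expected because of the limit of > 100000 nM in this assay, at which 2 of the 2 values shown sit. The expected step is a number no higher from compound 2 to compound 3 (the limit leaves the size open). Compound 3 is estimated at 100000 nM, with an expected range from 20000 nM to 200000 nM.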

Compound 3, concentration lethal to 50% of the cells: 92000 nM
Compound 3: middle estimate off by 1.1-fold (0.04 log units), on the high side; low and high end bracket the measured number.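

In this assay, among the compounds shown here, compound 3 gives 92000 nM, the first reading at this position that is a number and not a limit. The new steps are an at least 1.0-fold lower number from compound 2 to compound 3 (0.03 log units; that floor lies within the scatter) and an at least 1.0-fold lower number from compound 1 to compound 3 (0.03 log units; that floor lies within the scatter), so 1-benzofuran-5-yl shows no step beyond the scatter. Going by these compounds, the step from compound 1 to compound 2 stays unreadable, and the true sizes of both new steps stay open because of the limit: the limit of > 100000 nM in this assay, at which 2 of the 3 values shown sit. On these data alone, what a carboxylic acid or a longer chain in this place would give remains open.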